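Swapping 2-hydroxyphenyl for 4-methoxyphenyl: an expected shift

This account rests on a few compounds, and the source may have more. Where it says the series, first, only, none or still open, it means among the compounds named here.

Measured so far in a physicochemical assay for lipophilicity, measured as octanol-water partition; a lower number here means a more polar compound, a higher number a more lipophilic compound:
- compound 1 `O=C(COc1cccc2ccccc12)N/N=C/c1ccccc1Br` gives 4.81
- compound 2 `O=C(COc1cccc2ccccc12)N/N=C/c1ccc(Br)cc1` gives 4.81
- compound 3 `O=C(COc1cccc2ccccc12)N/N=C/c1ccccc1O` gives 3.73

Compound 3 has the lowest number of the three, and the gaps are large: a number 1.08 log units lower from compound 1 to compound 3 (beyond the scatter) and a number 1.08 log units lower from compound 2 to compound 3 (beyond the scatter). The next structure is compound 4 `COc1ccc(/C=N/NC(=O)COc2cccc3ccccc23)cc1`, and the change is 4-methoxyphenyl in place of 2-hydroxyphenyl on a carbon with a double bond to nitrogen, with 4-methoxyphenyl in place of 2-hydroxyphenyl on a carbon with a double bond to nitrogen.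

Within the data shown here, no measured compound carries methoxy, so no step speaks for it directly. The two large steps are the closest evidence, since each brings in 2-hydroxyphenyl, while compound 4 leaves it again. The swap of 2-bromophenyl for 4-bromophenyl gave no change at the digits printed from compound 1 to compound 2 (within the scatter), so a change of that kind need not matter on its own, though this was seen only for bromo. A rise smaller than the large steps is expected in this assay, which means an estimated a number 0.47 log units higher from compound 3 to compound 4 (beyond the scatter) and lies beyond the scatter. The estimate for compound 4 is 4.2 (expected range 3.8 to 4.6).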

Compound 4, partition coefficient: 3.77
Beside the measured number, compound 4's estimate is 0.43 log units above it, outside the stated range (below it).
By their numbers in this assay, from the lowest: compounds 3 and 4 (each within the scatter of the next); then compounds 1 and 2 (each within the scatter of the next).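

In this assay, the swap of 2-hydroxyphenyl for 4-methoxyphenyl gives a number 0.04 log units higher from compound 3 to compound 4 (within the scatter) and so shows that, at this place, a group with 0 hydrogen-bond donors can stand in for one with 1 without a change beyond the scatter. Methoxy also gives large steps when it replaces bromo, with a number 1.04 log units lower from compound 2 to compound 4 (beyond the scatter) and with a number 1.04 log units lower from compound 1 to compound 4 (beyond the scatter) in the swap of the whole ring group. The large gap from the bromo compounds is therefore not tied to 2-hydroxyphenyl alone, as it also appears with 4-methoxyphenyl.

From the compounds shown here alone, it remains open how 2-methoxyphenyl, 4-hydroxyphenyl or a phenyl ring carrying an amine or a carboxylic acid would behave at this place. Nothing measured here gives a reason for the closeness of compound 3 and compound 4.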